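The source may report more compounds than this note shows. Statements on the series, on what has been measured and on what is new or still open speak of the compounds shown alone.

The measured compounds:
Compound 1, `CC1=C(N2CC2)C(=O)C(CCCOC(N)=O)=C(N2CC2)C1=O`: in a functional assay on L1210 cells (Mus musculus), with a stated time of 12 days (a higher number here means a more potent compound, by a factor of ten per unit of this negative logarithm, a lower number a less potent compound), compound 1 gives 5.93.
Compound 2, `CCC(OC)C1=C(N2CC2)C(=O)C(C)=C(N2CC2)C1=O`: in this assay compound 2 gives 5.33.

Within the data shown here, compound 2 holds the lower of the two values known so far; compound 1 stands higher, and the single recorded step, a number 0.60 log units lower from compound 1 to compound 2 (beyond the scatter), exchanges the whole chain on the double-bonded ring carbon in one move. Compound 3, `COC(CO)C1=C(N2CC2)C(=O)C(C)=C(N2CC2)C1=O`, has not yet been measured. Its change from compound 2 is hydroxy in place of methyl on a saturated chain carbon, two bonds along the chain from a double-bonded ring carbon and an oxygen on a saturated carbon. Among the measured compounds shown here, no measured step alters one atom of the chain in this way. The step from compound 1 to compound 2 bears on it only loosely: it swapped one chain for another entirely and does not isolate the effect of a hydroxy group on a saturated chain carbon. A single pair cannot tell whether a chain carrying more oxygen favours the higher value. For compound 3 a step no larger than the scatter is expected, a number 0.17 log units higher from compound 2 to compound 3 (within the scatter), with wide uncertainty around it. Compound 3 is therefore expected to give 5.5, with a range from 4.9 to 6.1.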

Compound 3, logarithm of the reciprocal of the active concentration, log(1/C): 5.75
Compound 3: the middle estimate sits 0.25 log units below what was measured; low and high end bracket the measured number.
By their numbers in this assay, from the lowest: compound 2; then compounds 3 and 1 (each within the scatter of the next).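

In this assay, hydroxy in place of methyl on a saturated chain carbon, two bonds along the chain from a double-bonded ring carbon and an oxygen on a saturated carbon, gives a number 0.42 log units higher from compound 2 to compound 3 (beyond the scatter) and so moves the value by more than the scatter. Among these compounds, this is the first step confined to one atom of the chain, and it shows that this place responds to the change, which the earlier exchange of a whole chain could not isolate. The 2-hydroxy-1-methoxyethyl chain of compound 3 and the longer chain of compound 1 give a number 0.18 log units lower from compound 1 to compound 3 (within the scatter) on the double-bonded ring carbon, so the two chains cannot be told apart in this assay, although they differ in size and make-up. Nothing measured here accounts for the effect of the hydroxy group.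

Only methyl and hydroxy are shown at this place, so it remains open whether an amine, a carboxylic acid or a methoxy group there would give a similar value. Going by these compounds, it is also open whether a longer chain ending in hydroxy would keep, raise or lose the value seen with compound 3.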